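The compounds below may be only part of what the source reports. "The series", "measured", "known", "first", "only" and "open" are said of these compounds alone.

Measured compounds: compound 1 `N=C(N)NCCC[C@H](N)C(=O)NS(=O)(=O)OC[C@H]1OC[C@@H](n2cnc3c(N)ncnc32)[C@H](O)[C@@H]1O` gives 600 nM in a functional assay on PBMC cells (Homo sapiens) for inhibition; a higher number here means a weaker inhibitor, a lower number a stronger inhibitor; compound 2 `Nc1ncnc2c1ncn2[C@@H]1O[C@H](COS(=O)(=O)NC(=O)[C@@H]2CCN2)[C@@H](O)[C@H]1O` gives 600 nM; compound 3 `C[C@H](N)C(=O)NS(=O)(=O)OC[C@H]1OC[C@@H](n2cnc3c(N)ncnc32)[C@H](O)[C@@H]1O` gives 300 nM.

Compound 2 stands level with compound 1 at the digits shown, the two together the highest numbers of the three; compound 3 lies a step below them, but the step of a 2.0-fold lower number from compound 1 to compound 3 (0.30 log units; within the scatter) is within the scatter. Compound 4 `CSCC[C@H](N)C(=O)NS(=O)(=O)OC[C@H]1O[C@@H](n2cnc3c(N)ncnc32)[C@H](O)[C@@H]1O` differs from compound 2 in one place: 1-amino-3-(methylsulfanyl)propyl in place of azetidin-2-yl on a carbonyl carbon. Within the data shown here, only one measured step bears on this change, the step from compound 1 to compound 3, which exchanged one side chain on that carbon for hydrogen and stayed within the scatter. The data therefore do not support any change beyond the scatter, and a step of a 1.2-fold lower number from compound 2 to compound 4 (0.08 log units; within the scatter) is expected. Compound 4 is estimated at 500 nM, with a range from 200 nM to 1300 nM.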

Compound 4, half-maximal inhibitory concentration: 500 nM
The estimate for compound 4 equals the measured number at the digits printed; measured number inside the range.
By their numbers in this assay, from the lowest: compounds 3, 4, 1 and 2 (each within the scatter of the next).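

In this assay, 1-amino-3-(methylsulfanyl)propyl in place of azetidin-2-yl on a carbonyl carbon gives a 1.2-fold lower number from compound 2 to compound 4 (0.08 log units; within the scatter). This carbon therefore carries an open chain with sulfur and a four-membered ring with no difference beyond the scatter, a comparison that the earlier step, with no ring on either side, could not offer. Nothing available explains this result. On these data alone, whether a carboxylic acid or a longer chain without the amine on this carbonyl carbon would also stay within the scatter remains open.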